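Ring methyl on the piperazine of compound 2

This account rests on a few compounds, and the source may have more. Where it says the series, first, only, none or still open, it means among the compounds named here.

In an ADME assay on microsomes from liver (Mus musculus) for metabolic stability, read by LC-MS, with a stated time of 30 min, tested at 1 uM (on this read-out higher numbers stand for a more stable compound and lower numbers for a less stable compound), compound 1 (`CC(C)C1=C(C(=O)N2[C@H](C)CC[C@H]2C(=O)N2CCN(C)CC2)SC2=N[C@@](C)(c3ccc(Cl)cc3)[C@@H](c3ccc(Cl)cc3)N21`) gives 25% remaining, compound 2 (`CC[C@@H]1CC[C@@H](C(=O)N2CCN(C)CC2)N1C(=O)C1=C(C(C)C)N2C(=N[C@@](C)(c3ccc(Cl)cc3)[C@H]2c2ccc(Cl)cc2)S1`) gives 50% remaining and compound 3 (`CC(=O)N1CCN(C(=O)[C@@H]2CC[C@@H](C)N2C(=O)C2=C(C(C)C)N3C(=N[C@@](C)(c4ccc(Cl)cc4)[C@H]3c3ccc(Cl)cc3)S2)C[C@@H]1C`) gives 65% remaining. Compound 2 therefore holds the second highest of the three numbers, and both of the other values lie beyond the scatter from it.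

Compound 4 (`CC[C@@H]1CC[C@@H](C(=O)N2CCN(C)[C@H](C)C2)N1C(=O)C1=C(C(C)C)N2C(=N[C@@](C)(c3ccc(Cl)cc3)[C@H]2c2ccc(Cl)cc2)S1`) differs from compound 2 in one place: methyl in place of hydrogen on a saturated ring carbon. This turns 4-methylpiperazin-1-yl into 3,4-dimethylpiperazin-1-yl.

Among the compounds with values here, two measured steps bear on this change, neither of them directly. The first, a number 25 percentage points higher from compound 1 to compound 2 (beyond the scatter), also adds a methyl, but on a saturated chain carbon bound to a saturated ring carbon. From the compounds shown here alone, the second, a number 40 percentage points higher from compound 1 to compound 3 (beyond the scatter), replaces a whole group on a carbonyl carbon, so the share of any single methyl in it is unknown. Compound 3 at 65% carries a methyl on a saturated ring carbon and stands above compound 2, so a small rise is expected, well short of the second step. The expected change is a number 7 percentage points higher from compound 2 to compound 4 (within the scatter) and may not clear the scatter. For compound 4 the estimated value is 57% with an expected range of 38% to 75% remaining.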

Compound 4, percent of the compound remaining: 76%
Compound 4: middle estimate off by 19 percentage points, on the low side; the whole stated range lies below it.
By their numbers in this assay, from the lowest: compound 1; then compound 2; then compound 3; then compound 4.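

In this assay, going from 4-methylpiperazin-1-yl to 3,4-dimethylpiperazin-1-yl gives a number 26 percentage points higher from compound 2 to compound 4 (beyond the scatter). A single methyl on a saturated ring carbon, next to the ring atom that bears a methyl group and two ring bonds from the ring atom that bears a large group, is therefore enough on its own to move this read-out beyond the scatter, which the whole-group replacement in a number 40 percentage points higher from compound 1 to compound 3 (beyond the scatter) could not show. The step is modest in size, as is a number 25 percentage points higher from compound 1 to compound 2 (beyond the scatter), where the methyl enters on a saturated chain carbon bound to a saturated ring carbon, and no measurement at hand bears on the reason for either rise.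

Open questions are whether the gain depends on the stereochemistry at the new ring carbon and whether it survives with a hydroxymethyl group or a fluorine atom on that carbon in place of the methyl. The compounds shown also leave open whether the same ring methyl gives a comparable step on the core of compound 1, which carries a methyl rather than an ethyl on its saturated ring.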